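Amino in place of methoxy: cytotoxicity outlook

The source may hold more compounds than are shown below. What is called first, only, known or untested is meant among the compounds shown, and "the series" means these compounds.

Compound 2 `COc1nc(O)nc2c1ncn2[C@@H]1O[C@H](CO)[C@@H](O)[C@@]1(C)O` has only a limit in an ADME assay on CCRF-CEM cells (Homo sapiens) for cytotoxicity, read by trypan blue exclusion, with a stated time of 6 days; a lower number here means that less compound is tolerated, a higher number that more compound is tolerated: compound 2 gives > 100000 nM, a limit of the assay rather than a number. Compound 1 `C[C@@]1(O)[C@H](O)[C@@H](CO)O[C@H]1n1cnc2c(N)nc(N=[N+]=[N-])nc21` likewise sits at a limit, since compound 1 gives > 100000 nM in this assay. Both values thus rest at the limit of > 100000 nM in this assay, at which 2 of the 2 values shown sit, so compound 2 stands at no measured number. Compound 3 `C[C@@]1(O)[C@H](O)[C@@H](CO)O[C@H]1n1cnc2c(N)nc(O)nc21` differs from compound 2 by amino in place of methoxy on an aromatic carbon. Among the compounds with values here, no measured step connects such a pair, so no change beyond the scatter is expected in this assay, and a limit again seems most likely. Compound 3 is estimated at 100000 nM, within 30000 nM to 300000 nM, meaning an expected step of a number no higher from compound 2 to compound 3 (the limit leaves the size open).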

Compound 3, half-maximal cytotoxic concentration: > 100000 nM
Compound 3 was reported as a limit; the forecaster's own chance of this, stated with the estimate: 75%; the middle value sits exactly at the limit.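

In this assay compound 3 gives > 100000 nM, a limit, so the steps to compound 3 from compound 1 and compound 2 cannot be read: the limit of > 100000 nM in this assay, at which 3 of the 3 values shown sit.

The compounds shown leave open whether any change on the shared core yields a measurable number in this assay.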